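An N-Aryl Group Added to an Unsubstituted Lactam

A few compounds are considered here, and "the series" means these few. Any claim that something is new, unique, unknown or untested is made for them only; others in the source may bear on it.

Compound 2 `O=C1COc2ccc(-c3ccc(O)cc3)cc2N1` carries a free amide hydrogen on its shared core together with a phenol. In a functional assay on A549 cells (Homo sapiens) for antiproliferative activity, read by MTT assay, with a stated time of 72 h (a higher number here means a weaker inhibitor, a lower number a stronger inhibitor), compound 2 gives only a limit, > 40000 nM. Compound 2 therefore sits at the limit, (the limit of > 40000 nM in this assay, at which 1 of the 2 values shown sits), and no number places it. Compound 1 `COc1ccc(N2C(=O)COc3ccc(-c4cnc(OC)c(NS(=O)(=O)c5ccc(F)cc5)c4)cc32)cc1` differs from compound 2 in more than one place. In this assay compound 1 gives 1350 nM. Compound 3 `COc1cccc(N2C(=O)COc3ccc(-c4ccc(O)cc4)cc32)c1` is still to be measured. It differs from compound 2 by 3-methoxyphenyl in place of hydrogen on an amide-type nitrogen in a ring. Going by the values given here, no single step between measured compounds is known, so the direction must be judged from compound 1, whose value of 1350 nM in this assay comes with a substituted amide nitrogen. Compound 3 is expected to give about 15000 nM in this assay, between 3000 nM and 40000 nM, an expected step of an at least 2.6-fold lower number from compound 2 to compound 3 (0.42 log units; beyond the scatter) toward stronger inhibition, though a limit may again be all the assay reports.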

Compound 3, half-maximal inhibitory concentration: > 40000 nM
Compound 3 gave a limit, no number; the forecaster's own chance of this, stated with the estimate: 35%; middle value at least 2.6-fold (0.42 log units) from the limit.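

Compound 3 gives > 40000 nM in this assay and this is only a limit. Going by these compounds alone, compound 2 also stands at a limit, so no step between compound 2 and compound 3 can be read: the limit of > 40000 nM in this assay, at which 2 of the 3 values shown sit. On these data alone, whether 3-methoxyphenyl in place of hydrogen on the amide-type nitrogen changes the activity at all remains open, as does which of the differences in compound 1 goes with its measurable value.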